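Fluorine position swap on the benzyl arm: compound 2 to 4

The compounds below may be only part of what the source reports. "The series", "measured", "known", "first", "only" and "open" are said of these compounds alone.

Three members of the series have results in a functional assay on MDA-MB-231 cells (Homo sapiens) for cytotoxicity, read by MTT assay, with a stated time of 72 h; on this read-out higher numbers stand for weaker inhibition and lower numbers for stronger inhibition. Compound 1 `Nc1ccccc1NC(=O)c1ccc(Cn2cc(-c3ccc(NC(=O)NCc4cccnc4)cc3)nn2)cc1` returns only a limit, > 100000 nM, and no number in this assay. Compound 3 `Nc1ccc(CNC(=O)Nc2ccc(C(=O)Nc3ccccc3N)cc2)cn1` likewise returns only a limit, > 100000 nM, in this assay. Among the compounds with values here, compound 2 `Nc1ccccc1NC(=O)c1ccc(NC(=S)NCc2cccc(F)c2)cc1` is the single member with a measured number, 74000 nM in this assay, so it stands alone as the only quantified point. Against that one number stands (the limit of > 100000 nM in this assay, at which 2 of the 3 values shown sit).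

Compound 4 `Nc1ccccc1NC(=O)c1ccc(NC(=S)NCc2ccccc2F)cc1` has not been measured. It differs from compound 2 in one place: 2-fluorophenyl in place of 3-fluorophenyl on a saturated chain carbon bound to an amide-type nitrogen. Within the data shown here, no step between two measured compounds exists to calibrate a change of this kind, and the pairs among compounds 1, 2 and 3 each involve several differences at once, so they give no comparable reference.

The expected step is no change at the digits printed from compound 2 to compound 4 (within the scatter), which lies within the usual scatter and carries no set direction. For compound 4 the estimate in this assay is 74000 nM, with a range from 30000 nM to 150000 nM. Given that two of the three measured members returned only a limit, compound 4 may also come back as a limit rather than a number.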

Compound 4, half-maximal inhibitory concentration: > 100000 nM
Compound 4 was reported as a limit; the forecaster's own chance of this, stated with the estimate: 35%; middle value at least 1.3-fold (0.13 log units) away from the limit.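

In this assay, within the data shown here, this is the first pair that differs in one place, and it reads an at least 1.3-fold higher number from compound 2 to compound 4 (0.13 log units; that floor lies within the scatter). Compound 4 gives > 100000 nM, which is a limit and not a number, so the step has only a floor and its full size cannot be read. The swap from 3-fluorophenyl to 2-fluorophenyl, on a saturated chain carbon bound to an amide-type nitrogen, therefore adds no second quantified point, and compound 2 remains the only member with a number: the limit of > 100000 nM in this assay, at which 3 of the 4 values shown sit.

On these data alone, whether the fluorine position matters beyond the scatter stays open, as does whether any group on this arm can give stronger inhibition than compound 2 does. Among these compounds, a plain benzyl, a methoxybenzyl or a longer phenethyl chain in this place would show whether the fluorine or the arm itself accounts for the one number.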